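Five-membered ring for six-membered ring: compound 2 to compound 4

This account rests on a few compounds, and the source may have more. Where it says the series, first, only, none or still open, it means among the compounds named here.

Three compounds of the series have numbers in a functional assay on MGC-803 cells (Homo sapiens) for inhibition, read by MTT assay, with a stated time of 72 h; on this read-out higher numbers stand for weaker inhibition and lower numbers for stronger inhibition. Compound 1 `CN1CCN(C(=S)SCCCOc2ccc(C(=O)/C=C/c3cc(F)cc(F)c3)cc2)CC1` gives 16300 nM, compound 2 `O=C(/C=C/c1ccc(Cl)cc1)c1ccc(OCCSC(=S)N2CCOCC2)cc1` gives 11500 nM, and compound 3 `COc1cc(/C=C/C(=O)c2ccc(OCCSC(=S)N3CCCCC3)cc2)cc(OC)c1OC` gives 41300 nM. Compound 2 has the lowest of the three numbers; compound 1 sits within the scatter of it, while compound 3 lies beyond the scatter, with the higher number. Within the data shown here, since the other two compounds also differ from compound 2 in the substituents on their aromatic rings, no single-site step between measured compounds is available to lean on.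

Compound 4 `O=C(/C=C/c1ccc(Cl)cc1)c1ccc(OCCCSC(=S)N2CCCC2)cc1` is the unmeasured partner of compound 2. The change is a group of 9 heavy atoms (6 carbon, 1 nitrogen, 2 sulfur; one five-membered non-aromatic ring with 1 hetero atom) in place of a group of 9 heavy atoms (5 carbon, 1 nitrogen, 1 oxygen, 2 sulfur; one six-membered non-aromatic ring with 2 hetero atoms), on a saturated chain carbon, two bonds along the chain from an oxygen on an aromatic ring. The ring that enters carries one hetero atom instead of two, and the chain between the aromatic oxygen and the sulfur grows by one carbon.

With no measured step of this kind in the series, the expectation is a small step from compound 2 to compound 4 in this assay, toward a lower number, but not clearly beyond the scatter: the step expected is a 1.4-fold lower number from compound 2 to compound 4 (0.16 log units; within the scatter). Compound 4 is therefore estimated at 8000 nM, with a range from 3000 nM to 25000 nM.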

Compound 4, half-maximal inhibitory concentration: 34500 nM
The estimate for compound 4 lay 4.3-fold (0.63 log units) below the measured number; the measured number lies above the stated range.
By their numbers in this assay, from the lowest: compounds 2 and 1 (each within the scatter of the next); then compounds 4 and 3 (each within the scatter of the next).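

In this assay, the series now has its first step at a single place, a 3.0-fold higher number from compound 2 to compound 4 (0.48 log units; beyond the scatter), which shows that the number responds to the group on this saturated chain carbon, two bonds along the chain from an oxygen on an aromatic ring. Both groups hold 9 heavy atoms, so the step comes without a change in that count; what differs is the ring, one five-membered non-aromatic ring with 1 hetero atom in place of one six-membered non-aromatic ring with 2 hetero atoms, together with the length of the chain. Nothing at hand bears on why the number moves in this direction.

The step carries the ring change and the chain change together, so the compounds shown leave open how much of it belongs to each, and a compound changing only one of them would be needed to separate the two. Also open, as far as these compounds go, is how this read-out would respond at the same place to an acyclic dimethylamino group on the thiocarbonyl carbon, or to a still longer chain.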